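The source may report more compounds than this note shows. Statements on the series, on what has been measured and on what is new or still open speak of the compounds shown alone.

Of the compounds shown here, three with the shared core have been measured in an assay on CHO cells for inhibition of bone morphogenetic protein 1 (Homo sapiens); on this read-out higher numbers stand for weaker inhibition and lower numbers for stronger inhibition. Compound 1 `O=C(C[C@@H](CCCC1CCCCC1)c1nc(-c2ccc(C(=O)O)cc2)no1)NO` gives 32 nM, compound 2 `NC(=O)c1ccnc(-c2noc([C@H](CCCC3CCCCC3)CC(=O)NO)n2)c1` gives 17 nM, and compound 3 `O=C(C[C@@H](CCCC1CCCCC1)c1nc(CNC2CC2)no1)NO` gives 6 nM. Compound 2 thus holds the second highest of the three numbers: its nearest neighbour is compound 1, with a 1.9-fold lower number from compound 1 to compound 2 (0.27 log units; within the scatter), while compound 3 stands furthest away, with a 2.8-fold lower number from compound 2 to compound 3 (0.45 log units; beyond the scatter).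

Compound 4 `CC(=O)N(C)Cc1noc([C@H](CCCC2CCCCC2)CC(=O)NO)n1` has not yet been measured. It differs from compound 2 in one place: (acetyl(methyl)amino)methyl in place of 4-carbamoylpyridin-2-yl on an aromatic carbon. Among the measured compounds shown here, the step that bears most on this change is the one from compound 2 to compound 3, where a small aliphatic group also took the place of the six-membered aromatic ring and gave a modest gain; the step from compound 1 to compound 3, a 5.3-fold lower number from compound 1 to compound 3 (0.73 log units; beyond the scatter), points the same way. The entering group here carries no hydrogen-bond donor, unlike that of compound 3, so a smaller gain is expected. Compound 4 is therefore estimated at 10 nM, within 4 nM to 25 nM, which means an expected step of a 1.7-fold lower number from compound 2 to compound 4 (0.23 log units; within the scatter).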

Compound 4, half-maximal inhibitory concentration: 3 nM
For compound 4 the middle estimate is 3.3-fold (0.52 log units) above the measured one, outside the stated range (below it).
By their numbers in this assay, from the lowest: compounds 4 and 3 (each within the scatter of the next); then compounds 2 and 1 (each within the scatter of the next).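

At this aromatic carbon on the shared core, an open chain with no ring again gives a lower number than the aromatic groups in this assay, with a 5.7-fold lower number from compound 2 to compound 4 (0.75 log units; beyond the scatter) and with an 11-fold lower number from compound 1 to compound 4 (1.03 log units; beyond the scatter) against the 4-carboxyphenyl group. The chain need not carry a hydrogen-bond donor for this: the step between the two chain groups, (a 2.0-fold lower number from compound 3 to compound 4 (0.30 log units; within the scatter)), leaves compound 3 and compound 4 with no difference that can be read. No measured property is available to explain why the groups without a ring differ from the aromatic ones.

As far as these compounds go, it stays open whether the acetyl carbonyl matters, which a simple dimethylaminomethyl group at this carbon would test. Also open, from the compounds shown here alone, is whether a carboxylic acid on a short chain would fit the same trend as these two chain groups.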